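The source may report more compounds than this note shows. Statements on the series, on what has been measured and on what is new or still open speak of the compounds shown alone.

Measured compounds in this series:
- compound 1 `COc1cc(-c2ccc(C#N)cc2)ccc1Oc1cc(N)nc(Nc2ccc(C#N)cc2)n1`: 120000 nM
- compound 2 `Cc1cc(-c2ccccc2Cl)cc(C)c1Oc1cc(N)nc(Nc2ccc(C#N)cc2)n1`: 25100 nM
- compound 3 `Cc1ccccc1-c1cc(C)c(Oc2cc(N)nc(Nc3ccc(C#N)cc3)n2)c(C)c1`: 25600 nM

In a toxicity assay on MT4 cells (Homo sapiens) for cytotoxicity, read by MTT assay (on this read-out lower numbers stand for higher toxicity in this test and higher numbers for lower toxicity in this test), compound 2 gives 25100 nM, the lowest of the three numbers. Compound 3, with 25600 nM, sits within the scatter of compound 2: a 1.0-fold higher number from compound 2 to compound 3 (0.01 log units; within the scatter). Among the compounds with values here, compound 1, with 120000 nM, lies beyond the scatter from compound 2, but these two differ in more than one place and no single step links them.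

Compound 4 `Cc1cc(-c2ccccc2C#N)cc(C)c1Oc1cc(N)nc(Nc2ccc(C#N)cc2)n1` is not yet measured in this assay. It differs from compound 2 in one place: cyano in place of chloro on an aromatic carbon. The exchange sits on an aromatic carbon of a six-membered aromatic ring of carbon only, ortho to a large group.

Within the data shown here, only one measured step touches this position, the exchange of chloro for methyl, a 1.0-fold higher number from compound 2 to compound 3 (0.01 log units; within the scatter), which stayed within the scatter. Among the measured compounds shown here, no measured step exchanges chloro for cyano anywhere, so the bearing of the known steps is indirect. The expectation is therefore a step from compound 2 to compound 4 of no more than modest size, if anything toward a higher number, a 1.4-fold higher number from compound 2 to compound 4 (0.14 log units; within the scatter). Compound 4 is estimated at 35000 nM, with a range of 15000 nM to 90000 nM.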

Compound 4, half-maximal cytotoxic concentration: 25400 nM
Estimate against measurement, compound 4: 1.4-fold (0.14 log units) above; low and high end bracket the measured number.
By their numbers in this assay, from the lowest: compounds 2, 4 and 3 (each within the scatter of the next); then compound 1.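

In this assay, the aromatic carbon ortho to a large group has now carried chloro, methyl and cyano, and the new exchanges both stay within the scatter (a 1.0-fold higher number from compound 2 to compound 4 (0.01 log units; within the scatter); a 1.0-fold lower number from compound 3 to compound 4 (0.00 log units; within the scatter)). The earlier compounds shown here showed this for the exchange of chloro for methyl only; the change from 2-chlorophenyl to 2-cyanophenyl adds a second exchange at this place, bringing in a triple bond, one more heavy atom and a hydrogen-bond acceptor, and across compounds 2, 3 and 4 the read-out still does not separate the three groups. No measurement shown here gives a reason for this.

As far as these compounds go, whether the position stays as undemanding with an amine, a carboxylic acid or a longer chain in this place remains open, since the three groups seen so far are all small and uncharged. Compound 1 (120000 nM) differs from compounds 2, 3 and 4 in more than one place, so the part of its structure that goes with its number also remains unresolved.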